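This account rests on a few compounds, and the source may have more. Where it says the series, first, only, none or still open, it means among the compounds named here.

For the measured compounds named here, compound 1 `CC(C)CC1(O)CCN(C(=O)Nc2cc(Oc3ccc(F)cc3)cc(Oc3ccc(C(C)(C)C(=O)O)cc3)c2)CC1` was the compound with the higher of the two numbers so far in an ADME assay on the whole organism for pharmacokinetics, with Rattus norvegicus as the target, with a stated time of 24 h, at a dose of 1 mg/kg by the oral route (on this read-out higher numbers stand for higher exposure at the dose given and lower numbers for lower exposure), where compound 1 gives 390 ng.h/mL. Its neighbour, compound 2 `CC(C)CC1(O)CCN(C(=O)Nc2cc(Oc3ccc(F)cc3)cc(Oc3ccc(C4(C(=O)O)CC4)cc3)c2)CC1`, gives 320 ng.h/mL in this assay, and the step of a 1.2-fold lower number from compound 1 to compound 2 (0.09 log units; within the scatter) lies within the scatter. Compound 3 `CC(C)CC1(O)CN(C(=O)Nc2cc(Oc3ccc(F)cc3)cc(Oc3ccc(C(C)(C)C(=O)O)cc3)c2)C1` differs from compound 1 by 3-hydroxy-3-isobutylazetidin-1-yl in place of 4-hydroxy-4-isobutylpiperidin-1-yl on a carbonyl carbon. Going by the values given here, no measured step touches this part of the molecule: the one step that has been measured, from compound 1 to compound 2, concerns the carboxylic acid group on the other side of the shared core and was itself within the scatter, so it offers no guidance on the direction of this change. The exposure of compound 3 is therefore expected to stay close to that of compound 1, with a wide range, and the expected step is a 1.3-fold lower number from compound 1 to compound 3 (0.11 log units; within the scatter). Compound 3 is estimated at 300 ng.h/mL, within 80 ng.h/mL to 1100 ng.h/mL.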

Compound 3, area under the concentration-time curve: 1060 ng.h/mL
For compound 3 the middle estimate is 3.5-fold (0.55 log units) below the measured one; low and high end bracket the measured number.
By their numbers in this assay, from the lowest: compounds 2 and 1 (each within the scatter of the next); then compound 3.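

For the compounds shown here, on a carbonyl carbon, this position gives the first single change to move the number beyond the scatter: in this assay, 3-hydroxy-3-isobutylazetidin-1-yl in place of 4-hydroxy-4-isobutylpiperidin-1-yl gives a 2.7-fold higher number from compound 1 to compound 3 (0.43 log units; beyond the scatter). The earlier change at the carboxylic acid group, a 1.2-fold lower number from compound 1 to compound 2 (0.09 log units; within the scatter), gave no such signal, so the ring on the carbonyl carbon now stands out as the place where the number moved. The hydroxy and isobutyl groups stay in this change and the ring goes from six-membered to four-membered, but nothing available explains the higher exposure.

The compounds shown leave open where 3-hydroxy-3-isobutylpyrrolidin-1-yl would fall at this position. They also leave open whether the four-membered ring would give a similar step with an ethyl chain in place of isobutyl.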